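Nitro replacing hydrogen on the sulfonyl aryl, compound 4

This account rests on a few compounds, and the source may have more. Where it says the series, first, only, none or still open, it means among the compounds named here.

Measured so far in a functional assay on the whole organism for inhibition, with Rattus norvegicus as the target, read by paw edema, with stated times of 1 h and 0.5 h, at a dose of 100 mg/kg by the oral route; a lower number here means less inhibition, a higher number more inhibition at the dose given (going by the name of the read-out):
compound 1 `O=C(O)c1ccc(NC(=O)[C@@H]2CC(O)CN2S(=O)(=O)c2ccc([N+](=O)[O-])cc2)cc1` gives 44.1%
compound 2 `O=C(O)c1ccc(NC(=O)[C@@H]2CC(O)CN2S(=O)(=O)c2ccccc2)cc1` gives 33.9%
compound 3 `O=C(O)c1ccc(NC(=O)[C@@H]2CCCN2S(=O)(=O)c2ccccc2)cc1` gives 23.6%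

Compound 3 stands lowest of the three numbers in this assay. Its nearest neighbour is compound 2, reached by a number 10.3 percentage points lower from compound 2 to compound 3 (beyond the scatter), and the furthest is compound 1, which lies beyond compound 2 by a further a number 10.2 percentage points lower from compound 1 to compound 2 (beyond the scatter).

Compound 4 `O=C(O)c1ccc(NC(=O)[C@@H]2CCCN2S(=O)(=O)c2ccc([N+](=O)[O-])cc2)cc1` is not yet measured. It differs from compound 3 in one place: nitro in place of hydrogen on an aromatic carbon. Within the data shown here, the step that bears on this change is the one from compound 1 to compound 2, where hydrogen took the place of nitro on the same aromatic carbon with the hydroxy still present on the saturated ring; that step read a number 10.2 percentage points lower from compound 1 to compound 2 (beyond the scatter). Compound 4 runs the same change in the opposite direction, but on the ring without the hydroxy, so the size of the step is carried over as a modest rise in this assay, beyond the scatter, and is expected to come out as a number 10.4 percentage points higher from compound 3 to compound 4 (beyond the scatter).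

Compound 4 is therefore estimated at 34% in this assay, with a range from 22% to 46%.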

Compound 4, a percentage reported as inhibition, in the whole organism at one dose (the size of the read-out at that dose, not a potency): 42.1%
Compound 4: middle estimate off by 8.1 percentage points, on the low side; low and high end bracket the measured number.
By their numbers in this assay, from the lowest: compound 3; then compounds 2, 4 and 1 (each within the scatter of the next, the first and the last beyond it).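

In this assay, the change from phenyl to 4-nitrophenyl has now been read on the core without the hydroxy, with a number 18.5 percentage points higher from compound 3 to compound 4 (beyond the scatter), so nitro is followed by a step beyond the scatter on both cores, and the two steps agree: the same change on two cores in this assay, a number 10.2 percentage points lower (beyond the scatter) from compound 1 to compound 2 and a number 18.5 percentage points lower (beyond the scatter) from compound 4 to compound 3, 8.3 percentage points apart, within the scatter of two such steps

The hydroxy now has a reading with nitro present, a number 2 percentage points lower from compound 1 to compound 4 (within the scatter), which leaves compound 1 and compound 4 indistinguishable in this assay. This does not establish that the hydroxy counts for less when nitro is present, since the two hydroxy steps do not differ beyond the scatter: the same change on two cores in this assay, a number 10.3 percentage points lower (beyond the scatter) from compound 2 to compound 3 and a number 2 percentage points lower (within the scatter) from compound 1 to compound 4, 8.3 percentage points apart, within the scatter of two such steps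

The compounds shown carry only hydrogen or nitro on the aromatic carbon para to a large group, so it remains open whether an amine, a methoxy or a chlorine there would track with nitro or with hydrogen. Each reading also comes from a single dose, which leaves the dose response of compound 4 and compound 1 open, and a distinction between them might appear at other doses.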